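From Hydroxy to Chloro on an Aromatic Carbon

A few compounds are considered here, and "the series" means these few. Any claim that something is new, unique, unknown or untested is made for them only; others in the source may bear on it.

Among the measured compounds shown here, in a functional assay on HCT-116 cells (Homo sapiens) for cytotoxicity, read by MTT assay, with a stated time of 48 h (on this read-out lower numbers stand for stronger inhibition and higher numbers for weaker inhibition), compound 1 `COc1cc(/C=C/C(=O)C2=C(/C=C/c3ccc(O)c(OC)c3)NC(=S)NC2c2ccc(C)cc2)ccc1O` gives 50000 nM and compound 2 `COc1cc(/C=C/C(=O)C2=C(/C=C/c3ccc(O)c(OC)c3)NC(=S)NC2c2ccccc2O)ccc1O` gives 100000 nM, so compound 2 stands within the scatter of the only other measured compound. Compound 3 `COc1cc(/C=C/C(=O)C2=C(/C=C/c3ccc(O)c(OC)c3)NC(=S)NC2c2ccccc2Cl)ccc1O` keeps the shared core and changes one group: chloro in place of hydroxy on an aromatic carbon. This puts chloro in place of hydroxy on an aromatic carbon, ortho to a large group. For the measured compounds named here, the one measured step, a 2.0-fold higher number from compound 1 to compound 2 (0.30 log units; within the scatter), stays within the scatter, so no change beyond the scatter is expected in this assay. The estimated step is a 1.7-fold lower number from compound 2 to compound 3 (0.22 log units; within the scatter). For compound 3, the estimated value is 60000 nM, with a range of 20000 nM to 150000 nM.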

Compound 3, half-maximal inhibitory concentration: 100000 nM
Compound 3: middle estimate off by 1.7-fold (0.22 log units), on the low side; low and high end bracket the measured number.
By their numbers in this assay, from the lowest: compounds 1, 2 and 3 (each within the scatter of the next).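

In this assay, chloro in place of hydroxy gives no change at the digits printed from compound 2 to compound 3 (within the scatter) even though the hydrogen-bond donor and acceptor of the hydroxy are lost, so at this position the swap leaves no visible mark on the read-out. The wider comparison gives a 2.0-fold higher number from compound 1 to compound 3 (0.30 log units; within the scatter) and also stays within the scatter, so 2-chlorophenyl, 2-hydroxyphenyl and 4-methylphenyl cannot be told apart here. No measurement at hand explains this flat result. Still open, as far as these compounds go, is whether an amine, a carboxylic acid or a longer chain on this aromatic ring would move the number beyond the scatter.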